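Nitro substitution on the pendant phenyl of compound 1

A few compounds are considered here, and "the series" means these few. Any claim that something is new, unique, unknown or untested is made for them only; others in the source may bear on it.

Two compounds of this series have numbers in a functional assay on cells (Pituitary gland cell) for antagonist activity at Gonadotropin-releasing hormone receptor (Rattus norvegicus); a lower number here means a stronger inhibitor, a higher number a weaker inhibitor. Compound 1 `O=[N+]([O-])c1cc2c(OCCC3CCCCN3)c(-c3ccccc3)c(O)nc2cc1Cl` carries an unsubstituted phenyl on the shared core, and in this assay compound 1 gives 410 nM, the higher of the two numbers. Compound 2 `O=[N+]([O-])c1cc2c(OCCC3CCCCN3)c(-c3cc(C(F)(F)F)cc(C(F)(F)F)c3)c(O)nc2cc1Cl` carries a phenyl bearing two trifluoromethyl groups instead, and in this assay compound 2 gives 71 nM, a lower number and beyond the scatter. Going by the values given here, no single-point step between measured compounds is available, so the pair of compound 1 and compound 2 shows only that a substituted phenyl on this core went with the lower number.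

Compound 3 `O=[N+]([O-])c1cccc(-c2c(O)nc3cc(Cl)c([N+](=O)[O-])cc3c2OCCC2CCCCN2)c1` has not been measured in this assay. Against compound 1 the change is nitro in place of hydrogen on an aromatic carbon, on the pendant phenyl, meta to a large group. The expected step of a 2.1-fold lower number from compound 1 to compound 3 (0.31 log units; beyond the scatter) is a moderate drop, likely beyond the scatter, since compound 2 with its substituted phenyl gave 71 nM while compound 1 gave 410 nM. Compound 3 is expected to give about 200 nM, with a range from 60 nM to 700 nM.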

Compound 3, half-maximal inhibitory concentration: 100 nM
Estimate against measurement, compound 3: 2.0-fold (0.30 log units) above, within the range that was stated.
By their numbers in this assay, from the lowest: compounds 2 and 3 (each within the scatter of the next); then compound 1.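

Going by these compounds alone, the step from phenyl to 3-nitrophenyl is the first change confined to one place: in this assay it gives a 4.1-fold lower number from compound 1 to compound 3 (0.61 log units; beyond the scatter). A single nitro on the pendant phenyl, meta to a large group, is therefore enough on its own to produce a lower number beyond the scatter, which compound 2 could not show, as its phenyl differs from that of compound 1 by two trifluoromethyl groups. This position on the pendant phenyl thus accepts an added group of three heavy atoms without loss in this assay, and nothing available here bears on the reason for the step.

The compounds shown do not separate an effect specific to nitro from one shared by other groups on this carbon; an amine, a nitrile or a carboxylic acid in the same place would test that. They also leave open how nitro would read on a different carbon of the pendant phenyl, and whether a single trifluoromethyl in this place would give a step of similar size.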